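A Furan Replaces the Carbamate Chain on the Shared Core

A few compounds are considered here, and "the series" means these few. Any claim that something is new, unique, unknown or untested is made for them only; others in the source may bear on it.

Of the compounds shown here, two built on one shared core have been measured in a functional assay on PC-3 cells (Homo sapiens) for antiproliferative activity, read by MTT assay, with a stated time of 72 h; on this read-out lower numbers stand for stronger inhibition and higher numbers for weaker inhibition. Compound 1 `CCCSc1nc(Cl)c2c(n1)N(CCNC(=O)OC(C)(C)C)C(C(=O)N1CCN(C)CC1)N2` gives in this assay > 64000 nM, which is a limit of the assay and not a number. Compound 2 `CCCSc1nc(Cl)c2c(n1)N(Cc1ccccc1)C(C(=O)Nc1ccccc1)N2` likewise gives in this assay > 64000 nM, again a limit rather than a number. For the measured compounds named here, compound 1 therefore stands at the limit, and the one further value shown is a limit as well; together they make up (the limit of > 64000 nM in this assay, at which 2 of the 2 values shown sit). Going by the values given here, no step between measured compounds can be counted from these two limits, so no step beyond the scatter is known here.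

Compound 3 `CCCSc1nc(Cl)c2c(n1)N(Cc1ccco1)C(C(=O)N1CCN(C)CC1)N2` has not yet been measured in this assay. It differs from compound 1 in a single place: furan-2-yl in place of ((tert-butoxycarbonyl)amino)methyl on a saturated chain carbon bound to a nitrogen on an aromatic ring in a ring. Because compound 1 sits at the limit of > 64000 nM in this assay, at which 2 of the 2 values shown sit, the move to compound 3 can only be judged as an expectation, and the account expects compound 3 to stay near that limit, with no step beyond the scatter that the data would support in either direction. The step that this expectation means is a step that the limit leaves unreadable from compound 1 to compound 3. Compound 3 is thus estimated at 80000 nM, within an expected range from 30000 nM to 200000 nM.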

Compound 3, half-maximal inhibitory concentration: 11400 nM
Beside the measured number, compound 3's estimate is 7.0-fold (0.85 log units) above it; the measured number lies below the stated range.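

In this assay, furan-2-yl in place of ((tert-butoxycarbonyl)amino)methyl, on a saturated chain carbon bound to a nitrogen on an aromatic ring in a ring, gives an at least 5.6-fold lower number from compound 1 to compound 3 (0.74 log units; beyond the scatter). For the compounds shown here, this shows that a single change at this position can bring the shared core off the limit and to a readable number, which the earlier compounds, both sitting at the limit, could not show. The step is a bound and not a full size, and its true extent stays unknown because compound 1 gives only a limit of the assay: the limit of > 64000 nM in this assay, at which 2 of the 3 values shown sit.

The compounds shown leave open which part of the change counts: the furan-2-yl that enters, with its five-membered aromatic ring, or the ((tert-butoxycarbonyl)amino)methyl that leaves, with its hydrogen-bond donor. They also do not tell how a thiophen-2-yl or a free amine on the same saturated chain carbon would read, and the step holds for this one pair alone, so no trend at this position can be drawn from it.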